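This account rests on a few compounds, and the source may have more. Where it says the series, first, only, none or still open, it means among the compounds named here.

Measured in a functional assay on MIA PaCa-2 cells (Homo sapiens) for inhibition, read by MTT assay, with a stated time of 72 h; a higher number here means a weaker inhibitor of growth, a lower number a stronger inhibitor of growth:
compound 1, `O=S(=O)(NCCCCCCNCc1ccc(Br)cc1)c1c(Cl)cccc1Cl`, 14700 nM;
compound 2, `O=[N+]([O-])c1ccc(S(=O)(=O)NCCCCCCNCc2ccc(Br)cc2)cc1`, 9800 nM;
compound 3, `Cc1ccc(S(=O)(=O)NCCCCCCNCc2ccc(Br)cc2)cc1`, 12300 nM.

Compound 3 gives the second highest of the three numbers, but its neighbours sit close: the step of a 1.2-fold lower number from compound 1 to compound 3 (0.08 log units; within the scatter) and the step of a 1.3-fold higher number from compound 2 to compound 3 (0.10 log units; within the scatter) are both within the scatter, so nothing separates compound 3 from compound 1 or compound 2. The three compounds share one core, and they differ only in the group on the sulfonyl sulfur.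

Compound 4, `O=[N+]([O-])c1ccccc1S(=O)(=O)NCCCCCCNCc1ccc(Br)cc1`, carries the change (2-nitrophenyl in place of 4-methylphenyl on a sulfonyl sulfur). Going by the values given here, two measured steps bear on it. The step of a 1.3-fold higher number from compound 2 to compound 3 (0.10 log units; within the scatter) exchanges nitro and methyl on an aromatic carbon and stays within the scatter. The step of a 1.5-fold lower number from compound 1 to compound 2 (0.18 log units; within the scatter) brings in a nitrophenyl on the sulfonyl sulfur and also stays within the scatter. Every exchange of the aryl group seen so far has left this assay essentially unchanged, so compound 4 is expected to behave likewise, with a step of a 1.1-fold lower number from compound 3 to compound 4 (0.05 log units; within the scatter) that lies within the scatter and in no clear direction. Compound 4 is therefore estimated at 11000 nM, with a range from 5500 nM to 22000 nM.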

Compound 4, concentration for 50% growth inhibition: 11700 nM
Compound 4: middle estimate off by 1.1-fold (0.03 log units), on the low side, and the stated range covers the measured number.
By their numbers in this assay, from the lowest: compounds 2, 4, 3 and 1 (each within the scatter of the next).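

In this assay, going by these compounds alone, the 2-nitrophenyl group adds a test that the earlier compounds did not give: the same nitro group stands in a different place on the aromatic ring on the sulfonyl sulfur, and this relocation leaves the number within the scatter (a 1.2-fold higher number from compound 2 to compound 4 (0.08 log units; within the scatter)). The new group is just as inseparable from 4-methylphenyl (a 1.1-fold lower number from compound 3 to compound 4 (0.02 log units; within the scatter)) and from 2,6-dichlorophenyl (a 1.3-fold lower number from compound 1 to compound 4 (0.10 log units; within the scatter)), so nothing distinguishes any of the four aryl groups shown at this position, whichever substituent they carry and wherever it sits. No independent measurement is available to explain why these exchanges leave the growth read-out so flat.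

Going by these compounds, all four groups on the sulfonyl sulfur are substituted phenyl rings, so it remains open whether a different kind of group there, such as a simple alkyl chain, a pyridine ring or a phenyl ring bearing a carboxylic acid, would move the number beyond the scatter. On these data alone, it is also open whether the same flat response would hold with a shorter or longer chain in the shared core, or with another group in place of its bromine.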